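The compounds below may be only part of what the source reports. "The series", "measured", "known", "first", "only" and "open" are said of these compounds alone.

Values measured so far in a physicochemical assay for solubility, read by HPLC, measured as thermodynamic solubility, with a stated time of 24 h, at pH 1.5; on this read-out higher numbers stand for higher solubility and lower numbers for lower solubility
- compound 1 `CCCCc1ccc(NC(=O)COc2cc(C)nc3ccc(OC)cc23)cc1` at 240000 nM
- compound 2 `COc1ccc2nc(C)cc(OCC(=O)Nc3ccc4c(c3)CCC4)c2c1` at 240000 nM

Among the compounds with values here, compound 2 stands level with compound 1, the only other compound measured, and the two share the same reading at the digits reported. Compound 3 `COc1ccc2nc(C)cc(OCC(=O)Nc3ccc(C)cc3)c2c1` has not yet been measured. It keeps the rest of compound 2 but carries 4-methylphenyl in place of 2,3-dihydro-1H-inden-5-yl on an amide-type nitrogen. Within the data shown here, no measured pair of compounds differs in this one place, so the data offer no direct guide. The expectation rests only on compound 1 at 240000 nM and compound 2 at 240000 nM, which carry different groups on that nitrogen yet lie within the scatter of each other. In this assay no change beyond the scatter is therefore expected, and the estimated step is a 1.1-fold higher number from compound 2 to compound 3 (0.05 log units; within the scatter). Compound 3 is estimated at 270000 nM, with an expected range of 130000 nM to 550000 nM.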

Compound 3, solubility: 1200000 nM
Estimate against measurement, compound 3: 4.4-fold (0.65 log units) below, and the stated range ends below it.
By their numbers in this assay, from the lowest: compounds 1 and 2 (each within the scatter of the next); then compound 3.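

In this assay, the group on the amide-type nitrogen proves able to move the reading, which compound 1 and compound 2, level at the digits printed, gave no sign of. Placing 4-methylphenyl in place of 2,3-dihydro-1H-inden-5-yl gives a 5.0-fold higher number from compound 2 to compound 3 (0.70 log units; beyond the scatter), and hydrogen in place of propyl on a saturated chain carbon bound to an aromatic carbon gives a 5.0-fold higher number from compound 1 to compound 3 (0.70 log units; beyond the scatter). Two different changes at this place thus lead to compound 3, which stands highest of the three, with its steps to both others beyond the scatter.

Nothing measured here accounts for the size or direction of these steps. As far as these compounds go, it remains open how the reading would respond to an ethyl group, an amine or a carboxylic acid in place of the methyl of 4-methylphenyl.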